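Chlorophenyl variation in a bis-arylidene cyclohexanone series

A few compounds are considered here, and "the series" means these few. Any claim that something is new, unique, unknown or untested is made for them only; others in the source may bear on it.

Measured so far in a functional assay on MCF7 cells (Homo sapiens) for cytotoxicity, read by MTT assay, with a stated time of 72 h; a higher number here means a weaker inhibitor, a lower number a stronger inhibitor:
compound 1 `COc1cccc(/C=C2\CCC/C(=C\c3cccc(Cl)c3)C2=O)c1OC` gives 12000 nM.
compound 2 `COc1cccc(/C=C2\CCC/C(=C\c3ccc(Cl)cc3Cl)C2=O)c1OC` reaches only the assay limit, > 20000 nM.
compound 3 `COc1ccc(/C=C2\CCC/C(=C\c3ccccc3Cl)C2=O)cc1OC` gives 10400 nM.

Compound 3 holds the lowest of the two numbers shown; its nearest neighbour is compound 1, whose number sits higher by an amount within the usual scatter, so no order between the two can be claimed. The remaining value, that of compound 2, is a limit and not a number (the limit of > 20000 nM in this assay, at which 1 of the 3 values shown sits).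

Compound 4 `COc1ccc(/C=C2\CCC/C(=C\c3cc(Cl)cc(Cl)c3)C2=O)cc1OC` differs from compound 3 in one place: 3,5-dichlorophenyl in place of 2-chlorophenyl on a double-bonded chain carbon bound to a double-bonded ring carbon. Going by the values given here, one measured step bears on this, the move from a chlorophenyl to a dichlorophenyl on the same position of the core: an at least 1.6-fold higher number from compound 1 to compound 2 (0.22 log units; that floor lies within the scatter). Among the compounds with values here, that step is bounded by a limit rather than a number, and the dichlorophenyl of compound 4 is not the one of compound 2, so it gives direction more than size. The expectation in this assay is therefore a shift towards a higher number, of a size that may not stand clear of the scatter, with a real chance that compound 4 also returns only the limit. For compound 4 the estimate is 16000 nM, range 6000 nM to 40000 nM. This estimate means an expected step of a 1.5-fold higher number from compound 3 to compound 4 (0.19 log units; within the scatter).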

Compound 4, half-maximal inhibitory concentration: 3800 nM
The estimate for compound 4 lay 4.2-fold (0.62 log units) above the measured number; the whole stated range lies above it.
By their numbers in this assay, from the lowest: compound 4; then compounds 3 and 1 (each within the scatter of the next). At a limit, above all of these: compound 2.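

In this assay, going by these compounds alone, the change at this position, on a double-bonded chain carbon bound to a double-bonded ring carbon, gives the first step that stands clear of the scatter: a 2.7-fold lower number from compound 3 to compound 4 (0.44 log units; beyond the scatter), a modest shift. A dichlorophenyl at this position therefore need not raise the number, and the earlier step, an at least 1.6-fold higher number from compound 1 to compound 2 (0.22 log units; that floor lies within the scatter), does not carry over to this pair, although that step involves a different chlorophenyl, a different dichlorophenyl and a core that is not the core of compound 3. Nothing in the data at hand gives a cause for the lower number of compound 4.

It remains open whether the shift belongs to the added chlorine or to the placing of the chlorines, as no pair shown on one core separates these two changes. Also open, from the compounds shown here alone, is how far the trend at this position extends beyond chlorine-bearing phenyl groups, for instance to a phenyl carrying a dimethylamino group or a carboxylic acid.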